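Removing one fluoro from the core of compound 1

The compounds below may be only part of what the source reports. "The series", "measured", "known", "first", "only" and "open" are said of these compounds alone.

Measured compounds, with an assay on V79 cells for inhibition of cytochrome P450 11B2, mitochondrial (Homo sapiens), read by HTRF, with a stated time of 1 h; a lower number here means a stronger inhibitor, a higher number a weaker inhibitor:
Compound 1 `Fc1cc2nc(-c3cccnc3)n(C3CC3)c2cc1F` gives 2.1 nM.
Compound 2 `Cc1ccncc1-c1nc2cc(F)c(F)cc2n1C1CC1` gives 10.2 nM.
Compound 3 `N#Cc1cc2c(cc1F)nc(-c1cccnc1)n2C1CC1` gives 0.6 nM.

Among these three, compound 1 stands second highest: compound 3 sits a 3.5-fold lower number from compound 1 to compound 3 (0.54 log units; beyond the scatter) by swapping cyano in place of fluoro on an aromatic carbon, and compound 2 sits a 4.9-fold higher number from compound 1 to compound 2 (0.69 log units; beyond the scatter) by adding methyl in place of hydrogen on an aromatic carbon.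

Compound 4 `Fc1ccc2nc(-c3cccnc3)n(C3CC3)c2c1` differs from compound 1 by hydrogen in place of fluoro on an aromatic carbon. Neither measured step removes a fluoro outright; the step from compound 1 to compound 3 is the closer one, since it also touches a fluoro on the same ring, and it was modest in size, as was the step from compound 1 to compound 2. On that basis only a modest shift is expected in this assay, leaning toward a higher number, possibly within the scatter.

Compound 4 is estimated at 4 nM, expected between 1.5 nM and 12 nM, a step of a 1.9-fold higher number from compound 1 to compound 4 (0.28 log units; within the scatter).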

Compound 4, half-maximal inhibitory concentration: 4 nM
Beside the measured number, compound 4's estimate shows no gap at the digits printed; measured number inside the range.
By their numbers in this assay, from the lowest: compound 3; then compounds 1 and 4 (each within the scatter of the next); then compound 2.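

Replacing this fluoro, which sits ortho to a fluoro group, with hydrogen gives a 1.9-fold higher number from compound 1 to compound 4 (0.28 log units; within the scatter) in this assay. Unlike the methyl and cyano changes, this step does not move the number beyond the usual scatter, so compound 1 and compound 4 cannot be told apart here, and this one fluoro is not required for the low number seen with compound 1. No supporting measurement is available to explain this result.

The compounds shown leave open whether a larger group on this same carbon, such as a methoxy group or an amine, would be tolerated equally well. They also leave open whether hydrogen in this place would behave the same way alongside the cyano group of compound 3.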